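Aryl-amine swaps on one shared core: cytotoxicity notes

The compounds below may be only part of what the source reports. "The series", "measured", "known", "first", "only" and "open" are said of these compounds alone.

Compound 1 `COc1ccccc1Nc1nc(-c2cccc(F)c2)nc2ccc(F)cc12` gives only a limit, > 50000 nM, in a functional assay on MCF7 cells (Homo sapiens) for cytotoxicity, read by MTT assay, with a stated time of 48 h; on this read-out lower numbers stand for stronger inhibition and higher numbers for weaker inhibition.
Compound 2 `Fc1cccc(-c2nc(Nc3cccc(Cl)c3)c3cc(F)ccc3n2)c1` gives only a limit, > 50000 nM, in this assay.
Compound 3 `Fc1cccc(-c2nc(Nc3ccc(Br)cc3)c3cc(F)ccc3n2)c1` gives only a limit, > 50000 nM, in this assay.

Compound 3 thus stands at the limit shared by all three, (the limit of > 50000 nM in this assay, at which 3 of the 3 values shown sit). Compound 4 `Nc1cccc(Nc2nc(-c3cccc(F)c3)nc3ccc(F)cc23)c1` differs from it by 3-aminophenyl in place of 4-bromophenyl on a nitrogen on an aromatic ring. The measured steps a step that the two limits leave unreadable from compound 1 to compound 2, a step that the two limits leave unreadable from compound 1 to compound 3 and a step that the two limits leave unreadable from compound 2 to compound 3 are all unreadable, so no direction or size can be taken from them for the change to compound 4. The expected step of a number no higher from compound 3 to compound 4 (the limit leaves the size open) is accordingly set at no change beyond the scatter. Compound 4 is estimated at 50000 nM in this assay, within 10000 nM to 100000 nM, most likely again reported as a limit.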

Compound 4, half-maximal inhibitory concentration: > 50000 nM
Compound 4 gave a limit, no number (the forecaster's own chance of this, stated with the estimate: 70%); the middle value lies on the limit itself.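

No step can be read between compound 4 and compound 1, compound 2 or compound 3, as each value is only a limit: the limit of > 50000 nM in this assay, at which 4 of the 4 values shown sit.

The compounds shown leave open whether any of these aryl-amine swaps on the shared core changes the read-out in this assay.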